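The source may hold more compounds than are shown below. What is called first, only, known or untested is meant among the compounds shown, and "the series" means these compounds.

Compound 1, `COc1cccc(S(=O)(=O)c2ccc3c(c2)CCC[C@H]3CN)c1`, gives 0.398 nM in an assay on isolated protein for displacement of a labelled ligand from 5-hydroxytryptamine receptor 6 (Homo sapiens); on this read-out higher numbers stand for weaker inhibition and lower numbers for stronger inhibition.
Compound 2, `NC[C@@H]1CCCc2cc(S(=O)(=O)Cc3ccccc3)ccc21`, gives 158 nM in this assay.
Compound 3, `CN(C)S(=O)(=O)NC[C@@H]1CCCc2cc(S(=O)(=O)c3cccc(F)c3)ccc21`, gives 2 nM in this assay.

Among these three, compound 3 stands second highest: compound 1 lies at a lower number, beyond the usual scatter, and compound 2 lies at a much higher number, also beyond the scatter. Compound 4, `O=C1CN(C[C@@H]2CCCc3cc(S(=O)(=O)c4cccc(F)c4)ccc32)CCN1`, is not yet measured. It differs from compound 3 in one place: 3-oxopiperazin-1-yl in place of (dimethylsulfamoyl)amino on a saturated chain carbon bound to a saturated ring carbon. No pair of measured compounds isolates this change, so its size cannot be read from the numbers shown. The step of this change, a 1.5-fold higher number from compound 3 to compound 4 (0.18 log units; within the scatter), is expected to be modest, possibly within the scatter. Compound 4 is expected to give about 3 nM, within a range from 0.6 nM to 15 nM.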

Compound 4, inhibition constant: 6.31 nM
Compound 4: the middle estimate sits 2.1-fold (0.32 log units) below what was measured; low and high end bracket the measured number.
By their numbers in this assay, from the lowest: compound 1; then compound 3; then compound 4; then compound 2.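

Replacing (dimethylsulfamoyl)amino with 3-oxopiperazin-1-yl on this saturated chain carbon gives a 3.2-fold higher number from compound 3 to compound 4 (0.50 log units; beyond the scatter) in this assay, so this position accepts a six-membered non-aromatic ring at a modest but real cost. The two groups have the same counts of heavy atoms, hydrogen-bond donors and hydrogen-bond acceptors, so those counts alone do not fix the result. Nothing shown here explains the size of this step. Still open, as far as these compounds go, is how a morpholin-4-yl ring or an unsubstituted piperazin-1-yl ring would compare at this position. From the compounds shown here alone, whether the ring carbonyl matters also remains unknown.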